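This account rests on a few compounds, and the source may have more. Where it says the series, first, only, none or still open, it means among the compounds named here.

Compound 1 `CN1C(=O)CCC1(O)c1cccc(C(F)(F)F)c1` in a functional assay on the whole organism with Mus musculus as the target (a higher number here means that more compound is needed for the effect, a lower number that less compound is needed), gives 133 mg/kg. Compound 2 `CCN1C(=O)CCC1(O)c1cccc(C(F)(F)F)c1` reaches only a limit of this assay, > 100 mg/kg. The step that the limit leaves unreadable from compound 1 to compound 2 thus has no readable size because the limit of > 100 mg/kg in this assay, at which 1 of the 3 values shown sits, hides it; the change made is methyl in place of hydrogen on a saturated chain carbon bound to an amide-type nitrogen in a ring. Compound 3 `CC(C)NC(=O)CCC(=O)c1cccc(C(F)(F)F)c1` likewise gives only a limit in this assay, > 200 mg/kg, so that the limit of > 200 mg/kg in this assay, at which 1 of the 3 values shown sits, is all that is known of it. How the core of compound 3 differs from the core of compound 1 is not broken down here. Compound 4 `CCC(C)NC(=O)CCC(=O)c1cccc(C(F)(F)F)c1` carries the same kind of change as compound 2, (methyl in place of hydrogen on a saturated chain carbon, two bonds along the chain from an amide-type nitrogen), yet the place is not the same: here the methyl sits two bonds along the chain from an amide-type nitrogen, not bound to it in a ring. The step that the limit leaves unreadable from compound 3 to compound 4 is expected to be small, resting on the unreadable earlier step that the limit leaves unreadable from compound 1 to compound 2. Compound 4 is expected near 260 mg/kg, within 120 mg/kg to 600 mg/kg, most probably again reported as a limit.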

Compound 4, dose for half-maximal effect: > 200 mg/kg
Compound 4: no number, only a limit; the forecaster's own chance of this, stated with the estimate: 70%; the middle value is on the limit's open side.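

Within the data shown here, compound 3 and compound 4 both stand only as limits in this assay, so no step between them can be read. On these data alone, whether the methyl on the chain shifts the dose for half-maximal effect stays open.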